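The compounds below may be only part of what the source reports. "The series", "measured", "known", "first", "only" and "open" are said of these compounds alone.

Measured in a functional assay (blood) for inhibition, with Homo sapiens as the target (a higher number here means a weaker inhibitor, a lower number a stronger inhibitor), so far:
- compound 1 `CC(C)/C(=N\O)c1ccc(Sc2cc(F)cc(C3CCOCC3)c2)cc1` gives 300 nM
- compound 2 `CO[C@]1(c2cc(F)cc(Sc3ccc(/C(C)=N/O)cc3)c2)CCO[C@@H](C)C1` gives 40 nM
- compound 3 `C/C(=N\O)c1ccccc1Sc1cc(F)cc(C2CCOCC2)c1` reports only the assay limit > 10000 nM, not a number

Of the two numbers in this assay, compound 1 has the higher one; compound 2 sits at a lower number, beyond the scatter. Compound 3 sits at the limit of > 10000 nM in this assay, at which 1 of the 3 values shown sits, and gives no number to compare.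

Compound 4 `C/C(=N\OCC(=O)O)c1ccc(Sc2cc(F)cc(C3CCOCC3)c2)cc1` is not yet measured. It differs from compound 1 by a group of 8 heavy atoms (4 carbon, 1 nitrogen, 3 oxygen; no ring) in place of a group of 6 heavy atoms (4 carbon, 1 nitrogen, 1 oxygen; no ring), on an aromatic carbon, on an aromatic carbon of a six-membered aromatic ring of carbon only, para to a large group. Nothing among the measured compounds covers this change, so the direction rests on no shown step.

Compound 4 is expected to give 600 nM in this assay, between 150 nM and 3000 nM, which would mean an expected step of a 2.0-fold higher number from compound 1 to compound 4 (0.30 log units; within the scatter), a modest weakening that may still fall within the scatter.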

Compound 4, half-maximal inhibitory concentration: 740 nM
Beside the measured number, compound 4's estimate is 1.2-fold (0.09 log units) below it; the measured number falls inside the stated range.
By their numbers in this assay, from the lowest: compound 2; then compound 1; then compound 4. At a limit, above all of these: compound 3.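

In this assay the group of 8 heavy atoms in place of the group of 6 heavy atoms, on an aromatic carbon para to a large group, gives a 2.5-fold higher number from compound 1 to compound 4 (0.39 log units; beyond the scatter). This position therefore accepts the larger group, which adds a carbonyl, at only a modest cost, and compound 4 still gives a number rather than a limit. Nothing measured here accounts for the step. Still open, from the compounds shown here alone, is how an amine, an amide or a longer chain would fare at this position. Also open, going by these compounds, is how the same group of 8 heavy atoms would behave on the core of compound 2.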